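Allyl to Benzyl Swap and Cytotoxicity Toward J774.1 Cells

The source may hold more compounds than are shown below. What is called first, only, known or untested is meant among the compounds shown, and "the series" means these compounds.

Compound 1 `C=CCN1[C@H](c2ccc([N+](=O)[O-])cc2)C(C(=O)OCC)C(=O)C(C(=O)OCC)[C@@H]1c1ccc([N+](=O)[O-])cc1` and compound 2 `C=CCN1[C@H](c2ccc([N+](=O)[O-])cc2)C(C(=O)OC)C(=O)C(C(=O)OC)[C@@H]1c1ccc([N+](=O)[O-])cc1` share a core; how the two cores differ is not broken down here. In an ADME assay on J774.1 cells (Mus musculus) for cytotoxicity, with a stated time of 48 h (a higher number here means that more compound is needed for the effect, a lower number that less compound is needed), compound 1 gives only a limit of > 100 uM. In this assay compound 2 gives 50.3 uM. Compound 3 `COC(=O)C1C(=O)C(C(=O)OC)[C@H](c2ccc([N+](=O)[O-])cc2)N(Cc2ccccc2)[C@@H]1c1ccc([N+](=O)[O-])cc1` carries the change phenyl in place of vinyl on a saturated chain carbon bound to an amine nitrogen in a ring and in this assay compound 3 gives 18.4 uM, which is a 2.7-fold lower number from compound 2 to compound 3 (0.44 log units; beyond the scatter).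

Compound 4 `CCOC(=O)C1C(=O)C(C(=O)OCC)[C@H](c2ccc([N+](=O)[O-])cc2)N(Cc2ccccc2)[C@@H]1c1ccc([N+](=O)[O-])cc1` has not yet been measured. It differs from compound 1 by phenyl in place of vinyl on a saturated chain carbon bound to an amine nitrogen in a ring, the same change as that between compound 2 and compound 3, at the same place. Compound 1 stands at the limit of > 100 uM in this assay, at which 1 of the 3 values shown sits, so only a limit is known for it and the starting point of the step is uncertain. For compound 4 the step is expected to be an at least 1.6-fold lower number from compound 1 to compound 4 (0.22 log units; that floor lies within the scatter), resting on the measured 2.7-fold lower number from compound 2 to compound 3 (0.44 log units; beyond the scatter). Compound 4 is therefore estimated at 60 uM in this assay, most likely between 25 uM and 200 uM.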

Compound 4, concentration for half-maximal effect: > 100 uM
Compound 4 gave a limit, no number (the forecaster's own chance of this, stated with the estimate: 35%); middle value at least 1.6-fold (0.22 log units) from the limit.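

In this assay the step from compound 1 to compound 4 cannot be read, because both compounds stand at a limit and not at a number: the limit of > 100 uM in this assay, at which 2 of the 4 values shown sit.

The compounds shown leave open whether the allyl to benzyl change does to compound 1 what the one readable step shows, a 2.7-fold lower number from compound 2 to compound 3 (0.44 log units; beyond the scatter).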